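Swapping the aryl group on the piperazine of a chroman-type inhibitor

The source may report more compounds than this note shows. Statements on the series, on what has been measured and on what is new or still open speak of the compounds shown alone.

Compound 1: `COc1ccccc1N1CCN(C(=O)C2(C)CCc3c(C)c(O)c(C)c(C)c3O2)CC1` gives 15000 nM in a functional assay (brain) for inhibition, with Rattus norvegicus as the target; a lower number here means a stronger inhibitor, a higher number a weaker inhibitor.
Compound 2: `CCNc1cccnc1N1CCN(CC2(C)CCc3c(C)c(O)c(C)c(C)c3O2)CC1` gives 1000 nM in this assay.

Of the compounds shown here, two have been measured so far, and compound 2 stands as the stronger of the pair, with compound 1 coming in at a markedly higher number that lies beyond the usual scatter. Compound 1 and compound 2 differ in more than one place, so their two values say nothing on their own about either change.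

Compound 3, `COc1ccccc1N1CCN(CC2(C)CCc3c(C)c(O)c(C)c(C)c3O2)CC1`, is not yet measured. It carries the change (2-methoxyphenyl in place of 3-(ethylamino)pyridin-2-yl on an amine nitrogen in a ring). Among the measured compounds shown here, no measured pair isolates this change, so the direction has to be judged from the two values alone: compound 2 holds the lower number, and compound 1, which also bears the 2-methoxyphenyl group, holds the higher one. A modest loss in this assay is therefore expected, of about the size a 3.0-fold higher number from compound 2 to compound 3 (0.48 log units; beyond the scatter), with considerable uncertainty.

Compound 3 is estimated at 3000 nM, within the range 700 nM to 12000 nM.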

Compound 3, half-maximal inhibitory concentration: 1000 nM
Compound 3: the middle estimate sits 3.0-fold (0.48 log units) above what was measured; measured number inside the range.
By their numbers in this assay, from the lowest: compounds 2 and 3 (each within the scatter of the next); then compound 1.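

Putting 2-methoxyphenyl in place of 3-(ethylamino)pyridin-2-yl on the amine nitrogen in the ring gives no change at the digits printed from compound 2 to compound 3 (within the scatter) in this assay. This position therefore accepts the exchange of one aromatic ring for the other with no visible shift in this pair, even though the hydrogen-bond donor of the ethylamino group leaves. With 2-methoxyphenyl now present in both, compound 1 at 15000 nM and compound 3 at 1000 nM show that the gap between them does not come from the aryl group. Nothing available explains why the two aryl groups match.

From the compounds shown here alone, it remains open whether a plain phenyl or a 2-chlorophenyl group would also hold the value. One pair also cannot show whether a carboxylic acid at this position would do the same.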